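The compounds below may be only part of what the source reports. "The series", "measured", "known", "first", "only" and "open" are said of these compounds alone.

Compound 2 `CCOC(=O)Nc1cccc(-c2ccc(N(C)C)cc2)c1` gives 93% in an assay on COS-7 cells for inhibition of patatin-like phospholipase domain-containing protein 2 (Mus musculus), tested at 200 uM (on this read-out lower numbers stand for less inhibition and higher numbers for more inhibition at the one concentration tested (going by the name of the read-out)), the bottom of the two numbers in hand, yet compound 1 `COC(=O)Nc1cccc(-c2ccc(N(C)C)cc2)c1`, which gives 95%, lies within the scatter of it. Among the measured compounds shown here, the one measured step, a number 2 percentage points lower from compound 1 to compound 2 (within the scatter), sits at the same saturated chain carbon bound to an oxygen next to a carbonyl group. Compound 3 `CC(C)COC(=O)Nc1cccc(-c2ccc(N(C)C)cc2)c1` differs from compound 2 by isopropyl in place of methyl on a saturated chain carbon bound to an oxygen next to a carbonyl group. Because a number 2 percentage points lower from compound 1 to compound 2 (within the scatter) stayed within the scatter, no step beyond the scatter is expected here either. Compound 3 is estimated at 90%, with a range from 75% to 97%. The expected step is a number 3 percentage points lower from compound 2 to compound 3 (within the scatter).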

Compound 3, a percentage reported as inhibition, at one concentration (the size of the read-out at that concentration, not a potency): 90%
Estimate against measurement, compound 3: no gap at the digits printed; measured number inside the range.
By their numbers in this assay, from the lowest: compounds 3, 2 and 1 (each within the scatter of the next).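

In this assay, isopropyl in place of methyl gives a number 3 percentage points lower from compound 2 to compound 3 (within the scatter) and isopropyl in place of hydrogen gives a number 5 percentage points lower from compound 1 to compound 3 (within the scatter) on the same saturated chain carbon bound to an oxygen next to a carbonyl group. Thus, the position now accommodates a branched isobutoxycarbonyl group as well as the ethoxycarbonyl group, and even the step from compound 1 stays within the scatter. Nothing at hand offers an explanation for this result.

Going by these compounds, whether a longer chain, an amine or a carboxylic acid here would give a step beyond the scatter remains open. So does any difference among these compounds at other concentrations.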